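A few compounds are considered here, and "the series" means these few. Any claim that something is new, unique, unknown or untested is made for them only; others in the source may bear on it.

Compound 1 `CCNC(=O)c1cc(Oc2ccc(NC(=O)c3cc4cccnc4n(-c4ccccc4)c3=O)cc2)ccn1` gives 1120 nM in a functional assay on NCI-H460 cells (Homo sapiens) for antiproliferative activity, read by MTT assay, with a stated time of 72 h; on this read-out lower numbers stand for stronger inhibition and higher numbers for weaker inhibition.
Compound 2 `CCNC(=O)c1cc(Oc2ccc(NC(=O)c3cc4cccnc4n(-c4ccc(F)cc4)c3=O)cc2)ccn1` gives 220 nM in this assay.

Among the measured compounds shown here, of the two numbers measured so far, compound 2 has the lower one, and its gap to compound 1 lies beyond the usual scatter of such measurements: there is a 5.1-fold lower number from compound 1 to compound 2 (0.71 log units; beyond the scatter), which came from putting fluoro in place of hydrogen on an aromatic carbon. Compound 3 `CCNC(=O)c1cc(Oc2ccc(NC(=O)c3cc4cccnc4n(-c4ccc(Br)cc4F)c3=O)cc2)ccn1` carries a further change at the same side of the shared core: 4-bromo-2-fluorophenyl in place of 4-fluorophenyl on an aromatic nitrogen. For the measured compounds named here, only the step from compound 1 to compound 2 bears on this, and it concerns a single fluoro; nothing measured tells what a bromo, or a second fluoro placed differently on the same ring, does here. Going by the values given here, the one step in hand leaned toward stronger inhibition, so a small shift in the same direction, or none beyond the scatter, is the most that can be expected. For compound 3 the expected result in this assay is 180 nM, within a range from 60 nM to 600 nM. That estimate means a 1.2-fold lower number from compound 2 to compound 3 (0.09 log units; within the scatter), a step expected to stay close to the scatter.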

Compound 3, half-maximal inhibitory concentration: 1790 nM
Beside the measured number, compound 3's estimate is 9.9-fold (1.00 log units) below it, and the stated range ends below it.
By their numbers in this assay, from the lowest: compound 2; then compounds 1 and 3 (each within the scatter of the next).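

The group on the aromatic nitrogen does not reward every added halogen: in this assay the change to 4-bromo-2-fluorophenyl gives an 8.1-fold higher number from compound 2 to compound 3 (0.91 log units; beyond the scatter), a loss about as large as the gain in a 5.1-fold lower number from compound 1 to compound 2 (0.71 log units; beyond the scatter) that a single fluoro had brought. Measured against plain phenyl, the same group gives a 1.6-fold higher number from compound 1 to compound 3 (0.20 log units; within the scatter), so compound 3 and compound 1 cannot be told apart here, and the benefit of the 4-fluorophenyl group in compound 2 does not carry over to this more heavily substituted ring. This position therefore responds to the exact substituents on the ring, in either direction, but no measurement at hand explains why the number rose with this change.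

The step from compound 2 to compound 3 puts a bromo in place of one fluoro and adds a fluoro elsewhere on the ring, so the compounds shown cannot separate the contribution of each. Going by these compounds, it also remains open how this ring would behave with a chloro, a methoxy or an amine as its substituent.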